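The source may report more compounds than this note shows. Statements on the series, on what has been measured and on what is new or still open speak of the compounds shown alone.

Measured so far in an ADME assay on MT2 cells (Homo sapiens) for cytotoxicity, read by MTT assay; on this read-out lower numbers stand for higher toxicity in this test and higher numbers for lower toxicity in this test:
compound 1 `Clc1cccc(Cl)c1Cc1nnc(Nc2ccc(COCc3ccccn3)cc2)o1` gives > 100000 nM, which is a limit of the assay and not a number.
compound 2 `Clc1cccc(Cl)c1Cc1nnc(Nc2ccc(COCc3ccoc3)cc2)o1` gives 21000 nM.
compound 3 `Clc1cccc(Cl)c1Cc1nnc(Nc2ccc(COCc3ccco3)cc2)o1` gives 12000 nM.

Compound 3 carries the lowest of the two numbers; its nearest neighbour is compound 2, with a 1.8-fold lower number from compound 2 to compound 3 (0.24 log units; within the scatter), a gap that stays within the scatter, so no order between the two is claimed. The step of an at least 8.3-fold lower number from compound 1 to compound 3 (0.92 log units; beyond the scatter) and the step of an at least 4.7-fold lower number from compound 1 to compound 2 (0.67 log units; beyond the scatter) both run beyond the scatter, though each rests on the limit of > 100000 nM in this assay, at which 1 of the 3 values shown sits, and is therefore only a bound.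

Compound 4 `Clc1cccc(Cl)c1Cc1nnc(Nc2ccc(COCc3ccccc3)cc2)o1` is not yet measured. It differs from compound 3 as follows: phenyl in place of furan-2-yl on a saturated chain carbon bound to an oxygen on a saturated carbon. Within the data shown here, no measured step swaps furan-2-yl for phenyl at this place, so the bearing of the measured steps is indirect: the two furan-bearing compounds 2 and 3 give close numbers, and the move from pyridin-2-yl to either furan lowers the number by at least a modest step. The expectation for compound 4 in this assay is therefore a number close to that of compound 3, with the step of a 1.2-fold lower number from compound 3 to compound 4 (0.08 log units; within the scatter) expected to stay within the scatter. Compound 4 is estimated at 10000 nM, with a range from 4000 nM to 30000 nM.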

Compound 4, half-maximal cytotoxic concentration: 84000 nM
Estimate against measurement, compound 4: 8.4-fold (0.92 log units) below; the whole stated range lies below it.
By their numbers in this assay, from the lowest: compounds 3 and 2 (each within the scatter of the next); then compound 4. At a limit, above all of these: compound 1.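

In this assay, phenyl in place of furan-2-yl on a saturated chain carbon bound to an oxygen on a saturated carbon gives a 7.0-fold higher number from compound 3 to compound 4 (0.85 log units; beyond the scatter), and phenyl in place of furan-3-yl at the same place gives a 4.0-fold higher number from compound 2 to compound 4 (0.60 log units; beyond the scatter); both steps are modest and lie beyond the scatter. Among these compounds, a high number at this place is therefore not tied to pyridin-2-yl: a six-membered aromatic ring of carbon only also stands clear of the two furan compounds, and in these four compounds the division runs between the five-membered furans and the six-membered rings, with no compound going against it. Phenyl in place of pyridin-2-yl gives an at least 1.1-fold lower number from compound 1 to compound 4 (0.07 log units; that floor lies within the scatter); that floor lies within the scatter, so this step sets no order between the two compounds. The value of compound 1 is a limit and not a number: the limit of > 100000 nM in this assay, at which 1 of the 4 values shown sits.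

Ring size and the ring oxygen change together in these compounds, so the two remain unseparated; thiophen-2-yl or cyclopentyl at the same place would pull them apart. Going by these compounds, how a phenyl ring carrying an amine or a carboxylic acid would fall in this assay also stays open.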